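The compounds below may be only part of what the source reports. "The series", "measured", "known", "first", "only" and "open" are said of these compounds alone.

Two compounds have been measured in a functional assay on the whole organism (strain albino) with Rattus norvegicus as the target, read by paw edema, with stated times of 1 h and 4 h, at a dose of 50 mg/kg by the oral route; a lower number here means a weaker effect, a higher number a stronger effect of the compound at the dose given:
compound 1 `COc1ccc(Cl)cc1C(=O)Nc1ccc(C(=O)/C=C/c2ccccc2[N+](=O)[O-])cc1` gives 85.9%;
compound 2 `COc1ccc(C2CC(c3ccc(NC(=O)c4cc(Cl)ccc4OC)cc3)=NN2C)cc1` gives 93.2%.

Both numbers are high, and the gap between them lies within the usual scatter of repeated measurements, so compound 2 does not stand apart from compound 1 in this assay; the two are best read as alike. Going by the values given here, no pair of measured compounds differs in only one place, so there is no measured step to lean on.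

Compound 3 `COc1ccc(Cl)cc1C(=O)Nc1ccc(C2=NN(C)C(c3ccccc3[N+](=O)[O-])C2)cc1` is the compound still to be tested. It differs from compound 2 by a single exchange: 2-nitrophenyl in place of 4-methoxyphenyl on a saturated ring carbon. The group that enters, 2-nitrophenyl, is also found in compound 1, which in this assay gives 85.9%, a number close to that of compound 2.

With both measured compounds reading high and alike, the expected step is a number 5.2 percentage points lower from compound 2 to compound 3 (within the scatter), which is to say no change beyond the scatter in either direction. Compound 3 is therefore expected to give 88% in this assay, with a likely range from 74% to 97%.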

Compound 3, a percentage reported as activity, at one dose (the size of the read-out at that dose, not a potency): 99.5%
Beside the measured number, compound 3's estimate is 11.5 percentage points below it; the measured number lies above the stated range.
By their numbers in this assay, from the lowest: compounds 1, 2 and 3 (each within the scatter of the next, the first and the last beyond it).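

In this assay, going by these compounds alone, the exchange of 4-methoxyphenyl for 2-nitrophenyl on a saturated ring carbon amounts to a number 6.3 percentage points higher from compound 2 to compound 3 (within the scatter) and is the first measured step at this position. The two groups differ in their atoms and in their count of hydrogen-bond acceptors, and the entering group has a double bond outside the aromatic ring, yet this position takes either one with no change beyond the scatter, and the read-out stays high. Nothing measured here gives a reason why these two groups read alike.

On these data alone, both groups are substituted phenyl rings, so it remains open whether this carbon would keep the high read-out with something quite different in their place, such as a small methyl, a longer alkyl chain, an amine or a carboxylic acid. As far as these compounds go, it is also open whether the nitro group matters at all in its present place, which 4-nitrophenyl or plain phenyl could test, and whether compound 2 and compound 3 would still read alike at a lower dose, where the read-out would have more room to separate them.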